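The compounds below may be only part of what the source reports. "The series", "measured", "known", "first", "only" and "open" are said of these compounds alone.

The study centres on two pairs of compounds that share the same kind of structural change. Compound 1 `O=[N+]([O-])c1ccc(C(c2c[nH]c3ccc(Br)cc23)c2c[nH]c3ccc(Br)cc23)cc1` and compound 2 `CCCCCCCC(c1c[nH]c2ccc(Br)cc12)c1c[nH]c2ccc(Br)cc12` share one core, while compound 3 `N#Cc1ccc2[nH]cc(C(c3ccc([N+](=O)[O-])cc3)c3c[nH]c4ccc(C#N)cc34)c2c1` and compound 4 `CCCCCCCC(c1c[nH]c2ccc(C#N)cc12)c1c[nH]c2ccc(C#N)cc12` share another; how the two cores differ is not broken down here.

In a functional assay on HeLa cells (Homo sapiens) for inhibition, read by MTT assay, with a stated time of 48 h (on this read-out lower numbers stand for stronger inhibition and higher numbers for weaker inhibition), compound 1 gives 1500 nM. In this assay compound 2 gives 1300 nM. The change between them is heptyl in place of 4-nitrophenyl on a saturated chain carbon bound to two aromatic carbons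
The resulting step, a 1.2-fold lower number from compound 1 to compound 2 (0.06 log units; within the scatter), shows that the exchange leaves the read-out essentially unchanged on this core.

For compound 3, this assay gives only a limit, > 100000 nM, and not a number. Compound 3 thus sits at the limit (the limit of > 100000 nM in this assay, at which 1 of the 3 values shown sits).

Compound 4 differs from compound 3 by heptyl in place of 4-nitrophenyl on a saturated chain carbon bound to two aromatic carbons
Among the measured compounds shown here, this is the same change as that made between compound 1 and compound 2, at the same kind of position, so the earlier step is the only guide to what it does. On the core of compound 3, the starting point is already a limit, and a step of about the size seen earlier would be expected to keep compound 4 at or near that limit. The step expected in this assay is a step that the limit leaves unreadable from compound 3 to compound 4, and this expectation rests on the measured step of a 1.2-fold lower number from compound 1 to compound 2 (0.06 log units; within the scatter). Compound 4 is therefore expected to give about 120000 nM in this assay, with a likely range from 30000 nM to 500000 nM, and most probably only a limit will be reported.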

Compound 4, half-maximal inhibitory concentration: 7000 nM
For compound 4 the middle estimate is 17-fold (1.23 log units) above the measured one; measured number below the stated range.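

In this assay, among the compounds shown here, heptyl in place of 4-nitrophenyl on a saturated chain carbon bound to two aromatic carbons gives an at least 14-fold lower number from compound 3 to compound 4 (1.15 log units; beyond the scatter), so the size of this change's effect does not carry over from the core of compound 1 to the core of compound 3: the same change on two cores in this assay, a 1.2-fold lower number (0.06 log units; within the scatter) from compound 1 to compound 2 and an at least 14-fold lower number (1.15 log units; beyond the scatter) from compound 3 to compound 4, at least 12-fold (1.09 log units) apart, beyond the scatter of two such steps The value for compound 3 is a limit and not a number, so this step gives only a lower bound on the size of the change: the limit of > 100000 nM in this assay, at which 1 of the 4 values shown sits. With only two pairs, the result shows that the step measured on one core cannot be taken as a guide to the other, but it does not show what underlies the difference or how the same change would behave on any further core.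

The compounds shown leave open whether a longer chain, a shorter chain or an unsubstituted phenyl at the same place would give a step of similar size on each of the two cores. They also leave open whether a heptyl chain ending in an amine or a carboxylic acid would keep the number seen for compound 4, 7000 nM, in this assay.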